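Fused bicyclic amides in a phosphoribosyltransferase series

This account rests on a few compounds, and the source may have more. Where it says the series, first, only, none or still open, it means among the compounds named here.

Measured so far:
- compound 1 `O=C(NCc1ccc(S(=O)(=O)c2ccccc2)cc1)c1cc2ncccc2s1`: 400 nM
- compound 2 `O=C(NCc1ccc(S(=O)(=O)N2CCCCC2)cc1)c1ccn2cncc2c1`: 1700 nM

In an assay for inhibition of Nicotinamide phosphoribosyltransferase (Homo sapiens), read by mass spectrometry, with stated times of 15 min and 30 min (on this read-out higher numbers stand for weaker inhibition and lower numbers for stronger inhibition), compound 1 gives 400 nM. Within the data shown here, compound 2 gives 1700 nM in this assay, the highest of the two numbers seen; the gap to compound 1 lies beyond the scatter, though the two structures differ in more than one place and no single step connects them.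

Compound 3 `O=C(NCc1ccc(S(=O)(=O)N2CCCCC2)cc1)c1cnc2nccn2c1` keeps the whole of compound 2 apart from the group on the carbonyl carbon: a group of 9 heavy atoms (6 carbon, 3 nitrogen; one five-membered aromatic ring with 2 hetero atoms, one six-membered aromatic ring with 2 hetero atoms) in place of a group of 9 heavy atoms (7 carbon, 2 nitrogen; one five-membered aromatic ring with 2 hetero atoms, one six-membered aromatic ring with 1 hetero atom), on a carbonyl carbon. The outgoing group has one six-membered aromatic ring with 1 hetero atom; the incoming group has one six-membered aromatic ring with 2 hetero atoms and one more hydrogen-bond acceptor.

Among the measured compounds shown here, no measured pair shows the effect of such a swap, so the size of the step is not known from these data. Compound 3 is expected to give 600 nM in this assay, within 150 nM to 2400 nM. The estimated step of a 2.8-fold lower number from compound 2 to compound 3 (0.45 log units; beyond the scatter) is a modest move toward stronger inhibition, not far beyond the scatter.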

Compound 3, half-maximal inhibitory concentration: 3 nM
The estimate for compound 3 lay 200-fold (2.30 log units) above the measured number; measured number below the stated range.
By their numbers in this assay, from the lowest: compound 3; then compound 1; then compound 2.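

In this assay, the group on the carbonyl carbon proves to be a highly sensitive point in the series: with the rest of the molecule held constant, the swap gives a 570-fold lower number from compound 2 to compound 3 (2.75 log units; beyond the scatter). The change is small as counted, since both groups have 9 heavy atoms and one five-membered aromatic ring with 2 hetero atoms, while the incoming group has a six-membered aromatic ring with 2 hetero atoms instead of 1 hetero atom, plus one more hydrogen-bond acceptor. No supporting measurement accounts for a step of this size.

This single pair cannot show whether the gain follows the number of ring nitrogens or their arrangement within the group on the carbonyl carbon. Also open, from the compounds shown here alone, are whether the incoming group gives a similar step on the rest of the molecule of compound 1, and whether a methyl group or an amine on the incoming group keeps the number low.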